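Larger acyl groups on the amide of a hexafluoro-carbinol naphthalene core

The source may report more compounds than this note shows. Statements on the series, on what has been measured and on what is new or still open speak of the compounds shown alone.

Measured compounds in a functional assay (Sus scrofa) with sulfonylurea receptors; K-ATP channels (Homo sapiens) as the target; on this read-out higher numbers stand for larger maximal responses and lower numbers for smaller maximal responses:
compound 1 `CC(=O)Nc1c(C(O)(C(F)(F)F)C(F)(F)F)ccc2ccccc12`, 87%
compound 2 `CC(C)=CC(=O)Nc1c(C(O)(C(F)(F)F)C(F)(F)F)ccc2ccccc12`, 96%
compound 3 `O=C(Nc1c(C(O)(C(F)(F)F)C(F)(F)F)ccc2ccccc12)C1CC1`, 100%

All three compounds share the same core and differ only in the group on the carbonyl carbon of the amide. Compound 3 gives the highest number of the three in this assay; compound 2 lies closest to it, and that gap is within the scatter, so the two cannot be ordered, while compound 1 lies furthest off and that gap is beyond the scatter. The steps measured so far are a number 13 percentage points higher from compound 1 to compound 3 (beyond the scatter), a number 9 percentage points higher from compound 1 to compound 2 (within the scatter) and a number 4 percentage points higher from compound 2 to compound 3 (within the scatter).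

Compound 4 `Cc1cccc(C(=O)Nc2c(C(O)(C(F)(F)F)C(F)(F)F)ccc3ccccc23)c1` has not been measured. Against compound 3 it shows one change: 3-methylphenyl in place of cyclopropyl on a carbonyl carbon.

Within the data shown here, the steps that bear on this change are the two that alter the group on the carbonyl carbon away from methyl, a number 13 percentage points higher from compound 1 to compound 3 (beyond the scatter) and a number 4 percentage points higher from compound 2 to compound 3 (within the scatter); both are small, and only the first is beyond the scatter. Among the measured compounds shown here, no measured compound carries an aromatic ring at this place, so nothing in the data says whether a phenyl-type group behaves like cyclopropyl or falls back toward methyl. Since compound 3 already stands at the highest number seen, little room for a rise remains. Compound 4 is therefore expected to give 94% in this assay, within 80% to 105%, which means an expected step of a number 6 percentage points lower from compound 3 to compound 4 (within the scatter), not beyond the scatter.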

Compound 4, largest response reached (reported as efficacy), in percent of the reference or control that the assay uses: 97%
Compound 4: middle estimate off by 3 percentage points, on the low side; the range from low to high includes it.
By their numbers in this assay, from the lowest: compounds 1, 2, 4 and 3 (each within the scatter of the next, the first and the last beyond it).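

In this assay, among these compounds, the group on the carbonyl carbon can also be an aromatic ring, a kind of group none of the earlier compounds carried: with 3-methylphenyl in place of cyclopropyl, the step is a number 3 percentage points lower from compound 3 to compound 4 (within the scatter) even though the group grows from three heavy atoms to seven. Against the open-chain alkene the step is a number 1 percentage points higher from compound 2 to compound 4 (within the scatter) so compounds 2, 3 and 4 cannot be ordered, and a cyclic group at this place is not tied to the small cyclopropyl ring. Against the methyl amide the step is a number 10 percentage points higher from compound 1 to compound 4 (within the scatter) so compound 4, unlike compound 3, is not separated from compound 1 by more than the scatter, and no explanation of these results is available.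

The compounds shown leave open whether a plain phenyl group without the methyl gives the same response, and whether a phenyl ring carrying an amine or a carboxylic acid, or a longer alkyl chain on the carbonyl carbon, stays in this range in this assay as well. On these data alone, they also speak only to the largest response reached, so how much of each compound is needed to reach it remains unknown.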